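The source may report more compounds than this note shows. Statements on the series, on what has been measured and on what is new or still open speak of the compounds shown alone.

In a toxicity assay on MT2 cells (Homo sapiens) for cytotoxicity, read by XTT assay, with a stated time of 4 days (a higher number here means that more compound is tolerated, a lower number that less compound is tolerated), compound 1 `COc1ccc(CCOc2ccc(-c3c(C)nc(C)c([C@H](OC(C)(C)C)C(=O)O)c3N3CCC(C)(C)CC3)cc2)cc1` gives >= 33500 nM as a limit of the assay, not a number. Compound 2 `Cc1nc(C)c([C@H](OC(C)(C)C)C(=O)O)c(N2CCC(C)(C)CC2)c1-c1ccc(OCCc2cc(F)c(F)cc2F)cc1` gives >= 33500 nM as a limit too. That leaves compound 2 with no number of its own, and the pair shows the limit of >= 33500 nM in this assay, at which 2 of the 2 values shown sit, with no exception. The change to compound 3 `Cc1ccc(CCOc2ccc(-c3c(C)nc(C)c([C@H](OC(C)(C)C)C(=O)O)c3N3CCC(C)(C)CC3)cc2)s1` is 5-methylthiophen-2-yl in place of 2,4,5-trifluorophenyl on a saturated chain carbon, two bonds along the chain from an oxygen on an aromatic ring with 5-methylthiophen-2-yl in place of 2,4,5-trifluorophenyl on a saturated chain carbon, two bonds along the chain from an oxygen on an aromatic ring. Among the compounds with values here, the one measured step at this place is a step that the two limits leave unreadable from compound 1 to compound 2 and gives no size to carry over, though both groups seen there leave the compound at the limit. No step beyond the scatter is therefore expected in this assay and the estimated step is a number no higher from compound 2 to compound 3 (the limit leaves the size open) for now. For compound 3 the estimate is 33500 nM with an expected range from 17000 nM to 50000 nM and a limit as the likeliest report.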

Compound 3, half-maximal cytotoxic concentration: >= 25000 nM
Compound 3 ended at the assay's limit; the forecaster's own chance of this, stated with the estimate: 80%; the middle value does not contradict the limit.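

In this assay, within the data shown here, compound 1, compound 2 and compound 3 all report limits of the assay, not numbers, and no step among them can be read. The compounds shown leave open where the half-maximal cytotoxic concentration of each lies and whether exchanging these groups changes it.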